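Removing the Methoxy Group from Compound 2

A few compounds are considered here, and "the series" means these few. Any claim that something is new, unique, unknown or untested is made for them only; others in the source may bear on it.

Compound 2 `COC(C)(C)CC1n2cncc2CN([C@@H](C)c2ccc(Cl)cc2)S1(=O)=O` holds the lower of the two numbers recorded in an assay on cells for inhibition of cytochrome P450 11B1, mitochondrial (Homo sapiens) (a lower number here means a stronger inhibitor, a higher number a weaker inhibitor), where compound 2 gives 20.6 nM. Within the data shown here, the only other compound measured, compound 1 `C[C@@H](c1ccc(Cl)cc1)N1Cc2cncn2C(CC2(C)COC2)S1(=O)=O`, gives 340 nM in this assay, and the step of a 17-fold lower number from compound 1 to compound 2 (1.22 log units; beyond the scatter) separates them. Compound 3 `CC(C)CC1n2cncc2CN([C@@H](C)c2ccc(Cl)cc2)S1(=O)=O` differs from compound 2 by hydrogen in place of methoxy on a saturated chain carbon bound to three saturated chain carbons. Among the measured compounds shown here, no measured step matches this change; the one step seen moved an ether and bears on it only loosely. Compound 3 is therefore expected to show a step of a 1.9-fold higher number from compound 2 to compound 3 (0.29 log units; within the scatter). Compound 3 is estimated at 40 nM in this assay, with a range from 10 nM to 150 nM.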

Compound 3, half-maximal inhibitory concentration: 76 nM
For compound 3 the middle estimate is 1.9-fold (0.28 log units) below the measured one; the range from low to high includes it.
By their numbers in this assay, from the lowest: compound 2; then compound 3; then compound 1.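

In this assay the loss of methoxy gives a 3.7-fold higher number from compound 2 to compound 3 (0.57 log units; beyond the scatter) and shows that this position responds to that single group. Replacing 3-methyloxetan-3-yl with isopropyl gives a 4.5-fold lower number from compound 1 to compound 3 (0.65 log units; beyond the scatter) and places the isopropyl compound in the middle, so the order runs 1-methoxy-1-methylethyl, isopropyl, then 3-methyloxetan-3-yl. No evidence is available to explain this order. Still open, from the compounds shown here alone, is how a hydroxyl in place of methoxy would compare at this carbon, and whether an ethoxy group or an amine would match compound 2.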